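The source may hold more compounds than are shown below. What is called first, only, known or untested is meant among the compounds shown, and "the series" means these compounds.

In a functional assay on K562 cells (Homo sapiens) for inhibition, read by spectrophotometry and sulforhodamine B assay, with a stated time of 48 h (a higher number here means a weaker inhibitor of growth, a lower number a stronger inhibitor of growth), compound 1 `Cc1ccc(N2C(=O)CS/C2=N/N=C/c2c[nH]c3ccc(Br)cc23)cc1` gives 10 nM and compound 2 `S=C(N/N=C/c1c[nH]c2ccc(Br)cc12)Nc1cccc2ccccc12` gives 5290 nM as the higher of the two numbers, a gap beyond the scatter. Compound 3 `S=C(N/N=C/c1c[nH]c2ccccc12)Nc1cccc2ccccc12` differs from compound 2 by hydrogen in place of bromo on an aromatic carbon in one place, with hydrogen in place of bromo on an aromatic carbon. Within the data shown here, the two measured compounds differ in more than one place, so no measured step isolates this change. No step beyond the scatter is expected in this assay in either direction. The estimated step of a 1.1-fold higher number from compound 2 to compound 3 (0.05 log units; within the scatter) stays within the scatter. For compound 3 the expected value is 6000 nM within an estimated range from 2000 nM to 18000 nM in these notes.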

Compound 3, concentration for 50% growth inhibition: 10 nM
Compound 3: middle estimate off by 600-fold (2.78 log units), on the high side; the whole stated range lies above it.
By their numbers in this assay, from the lowest: compounds 1 and 3 (each within the scatter of the next); then compound 2.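

Hydrogen in place of bromo on this aromatic carbon gives a 530-fold lower number from compound 2 to compound 3 (2.72 log units; beyond the scatter) in this assay, so in this pair the position is far from silent and bromo goes with the weaker growth inhibition. Among these compounds, this is the first step that isolates one change, which the earlier pair could not do. No evidence at hand accounts for the size of this step.

From the compounds shown here alone, whether chloro, methoxy or an amine on this carbon would read closer to compound 2 or to compound 3 remains open. Also open, going by these compounds, is whether removing bromo has any comparable effect on the core of compound 1.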